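Compound 3: a 5-fluoropyridin-2-yl group enters

The source may report more compounds than this note shows. Statements on the series, on what has been measured and on what is new or still open speak of the compounds shown alone.

In a physicochemical assay for lipophilicity (on this read-out higher numbers stand for higher lipophilicity and lower numbers for lower lipophilicity), compound 1 `CN1CCN(c2cc(C(F)(F)F)ccc2[C@H]2CCOc3cc(S(=O)(=O)Nc4nccs4)ccc32)CC1` gives 2.1. Compound 2 `Cc1nc(-c2cc(C(F)(F)F)ccc2[C@H]2CCOc3cc(S(=O)(=O)Nc4nccs4)ccc32)co1` gives 2.9, the higher of the two numbers and beyond the scatter of compound 1. Compound 3 `O=S(=O)(Nc1nccs1)c1ccc2c(c1)OCC[C@@H]2c1ccc(C(F)(F)F)cc1-c1ccc(F)cn1` carries 5-fluoropyridin-2-yl in place of 2-methyl-1,3-oxazol-4-yl on an aromatic carbon, ortho to a large group and meta to a trifluoromethyl group: 5-fluoropyridin-2-yl in place of 2-methyl-1,3-oxazol-4-yl on an aromatic carbon. Among the measured compounds shown here, no measured step starts from 2-methyl-1,3-oxazol-4-yl, so the only guide is indirect. Measured against a number 0.80 log units higher from compound 1 to compound 2 (beyond the scatter), a modest step, a smaller one is expected here, since the leaving and the entering group each hold one aromatic ring with no net charge. A small rise in this assay is expected, and the estimated step is a number 0.30 log units higher from compound 2 to compound 3 (within the scatter). For compound 3 the estimate is 3.2, with an expected range from 2.7 to 3.7.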

Compound 3, distribution coefficient: 3.5
The estimate for compound 3 lay 0.30 log units below the measured number; low and high end bracket the measured number.
By their numbers in this assay, from the lowest: compound 1; then compound 2; then compound 3.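

The earlier compounds shown here showed only 4-methylpiperazin-1-yl giving way to an aromatic ring at this position. Here one group holding a single aromatic ring replaces another, and this assay still separates them, with a number 0.60 log units higher from compound 2 to compound 3 (beyond the scatter), so the number depends on which ring sits at this position and not only on whether a ring is present; the full span at this position, a number 1.40 log units higher from compound 1 to compound 3 (beyond the scatter), is the largest step shown. Nothing available explains the gap between the two aromatic groups.

From the compounds shown here alone, the exchange changes ring size, hetero atoms and the attached fluorine or methyl group at once, so the share of each stays open; a plain pyridin-2-yl group would bear on this. Going by these compounds, how a carboxylic acid or a primary amine at this position would read in this assay also remains open.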